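The compounds below may be only part of what the source reports. "The series", "measured", "known", "first", "only" and "open" are said of these compounds alone.

Measured in a functional assay on SK-OV-3 cells (Homo sapiens) for inhibition, read by CCK-8 assay, with a stated time of 70 h; a higher number here means a weaker inhibitor, a lower number a stronger inhibitor:
- compound 1 `Nc1ccccc1COc1ccc(OCCOCCNC2CCCC2)cc1`: 14000 nM
- compound 2 `COC(=O)c1ccc(COc2ccc(OCCOCCNC3CCCC3)cc2)cc1`: 6990 nM
- compound 3 `c1ccc(COc2ccc(COc3ccc(OCCOCCNC4CCCC4)cc3)cc2)cc1`: 10000 nM

All three compounds carry the same cyclopentyl-amine chain on the shared core and differ only in the group attached through the benzylic oxygen. Compound 2 stands level with its two neighbours, since neither of its steps leaves the scatter: a 2.0-fold lower number from compound 1 to compound 2 (0.30 log units; within the scatter), and a 1.4-fold higher number from compound 2 to compound 3 (0.16 log units; within the scatter). None of the three can therefore be called the better inhibitor.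

The next compound, compound 4 `CCOc1ccc(OCCOCCNC2CCCC2)cc1`, cuts much deeper. The change is methyl in place of 4-(methoxycarbonyl)phenyl on a saturated chain carbon bound to an oxygen on an aromatic ring.

The two measured steps give only limited guidance. Both swapped one ring-bearing group for another, and both stayed within the scatter, so changes of that kind have so far shifted this assay very little. For the measured compounds named here, no measured compound lacks that outer ring, which makes this step an extrapolation. A modest rise in the number is expected, though a result within the scatter would be no surprise.

The expected change is a 2.6-fold higher number from compound 2 to compound 4 (0.41 log units; beyond the scatter). For compound 4 the estimate is 18000 nM, with an expected range of 7000 nM to 50000 nM.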

Compound 4, half-maximal inhibitory concentration: 90500 nM
Estimate against measurement, compound 4: 5.0-fold (0.70 log units) below; measured number above the stated range.
By their numbers in this assay, from the lowest: compounds 2, 3 and 1 (each within the scatter of the next); then compound 4.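

Among the compounds shown, the earlier swaps of one ring-bearing group for another at this position stayed within the scatter, but replacing the group with methyl is a different kind of change. In this assay this replacement gives a 13-fold higher number from compound 2 to compound 4 (1.11 log units; beyond the scatter) and also a 6.5-fold higher number from compound 1 to compound 4 (0.81 log units; beyond the scatter), so the position is far from indifferent to what it carries: the 4-(methoxycarbonyl)phenyl group that leaves has 10 heavy atoms and an aromatic ring, while the methyl that enters has 1 heavy atom and no ring. No experimental evidence is available to explain this rise in the number.

The compounds shown leave open whether the aromatic ring itself matters or simply the larger number of atoms at this position, a question that a cyclohexyl group or a longer chain such as butyl on the same carbon could help to separate. They also leave open how little is needed to recover the lower numbers, since an unsubstituted phenyl group on that carbon is not among them.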